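Benzofuran on a core resting at the assay limit

A few compounds are considered here, and "the series" means these few. Any claim that something is new, unique, unknown or untested is made for them only; others in the source may bear on it.

Compound 1 `CNc1ncnc2c1c(-c1cccs1)cn2[C@@H]1O[C@H](CO)[C@@H](O)[C@H]1O` and compound 2 `CNc1ncnc2c1c(-c1ccccc1)cn2[C@@H]1O[C@H](CO)[C@@H](O)[C@H]1O` share a core and were tested in a functional assay on HeLa S3 cells (Homo sapiens) for antiproliferative activity, read by XTT assay, with a stated time of 72 h (on this read-out lower numbers stand for stronger inhibition and higher numbers for weaker inhibition), for antiproliferative activity. Compound 1 gives > 20000 nM as a limit. Compound 2 gives > 20000 nM as a limit too. It therefore stands at the limit of > 20000 nM in this assay, at which 2 of the 2 values shown sit, and has no exact number. Going by the values given here, the only measured step that the two limits leave unreadable from compound 1 to compound 2 offers no size to carry forward. Compound 3 `CNc1ncnc2c1c(-c1cc3ccccc3o1)cn2[C@@H]1O[C@H](CO)[C@@H](O)[C@H]1O` carries 1-benzofuran-2-yl in place of phenyl on an aromatic carbon and awaits measurement. No step beyond the scatter is expected in this assay and the estimated step is a number no higher from compound 2 to compound 3 (the limit leaves the size open) on this reasoning. Compound 3 is expected at 20000 nM with an estimated range from 8000 nM to 40000 nM and will probably be reported only as a limit.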

Compound 3, half-maximal inhibitory concentration: > 20000 nM
Compound 3 was reported as a limit; the forecaster's own chance of this, stated with the estimate: 80%; the middle value lies on the limit itself.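

In this assay compound 3 gives > 20000 nM, a limit. No step among compound 1, compound 2 and compound 3 can be read, as all three rest on one value: the limit of > 20000 nM in this assay, at which 3 of the 3 values shown sit.

The compounds shown leave open how thiophen-2-yl, phenyl and 1-benzofuran-2-yl rank against one another on the shared core.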